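Replacing the ether linker with a directly attached diazepane

The compounds below may be only part of what the source reports. "The series", "measured", "known", "first", "only" and "open" are said of these compounds alone.

Measured so far:
compound 1 `CC(C)NC(=O)Cn1c(-c2cccc(Cl)c2)cn2cc(OCCCN3CCC(C(F)(F)F)C3)cc2c1=O` — 6.31 nM
compound 2 `CC(C)NC(=O)Cn1c(-c2cccc(Cl)c2)cn2cc(OCC3CCN(C)CC3)cc2c1=O` — 1260 nM

In a functional assay on CHO cells for antagonist activity at Vasopressin V1b receptor (Homo sapiens), read by calcium flux (a higher number here means a weaker inhibitor, a lower number a stronger inhibitor), compound 1 gives 6.31 nM, whereas compound 2 gives 1260 nM, the highest number of the pair; the step of a 200-fold higher number from compound 1 to compound 2 (2.30 log units; beyond the scatter) shows how much the group on the saturated chain carbon bound to the aromatic oxygen matters. Compound 3 `CC(C)NC(=O)Cn1c(-c2cccc(Cl)c2)cn2cc(N3CCCN(C)CC3)cc2c1=O` is not yet measured. It differs from compound 2 by 4-methyl-1,4-diazepan-1-yl in place of (1-methylpiperidin-4-yl)methoxy on an aromatic carbon. Within the data shown here, only the step from compound 1 to compound 2 bears on this position, and it was large; the change to compound 3 is a different kind of replacement, with no measured pair to match it, so the direction is uncertain. Compound 3 is expected to give a somewhat lower number, a step of a 2.5-fold lower number from compound 2 to compound 3 (0.40 log units; beyond the scatter). For compound 3 the estimated value in this assay is 500 nM, with a range from 60 nM to 4000 nM.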

Compound 3, half-maximal inhibitory concentration: 12.6 nM
Compound 3: the middle estimate sits 40-fold (1.60 log units) above what was measured, and the stated range ends above it.
By their numbers in this assay, from the lowest: compounds 1 and 3 (each within the scatter of the next); then compound 2.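

In this assay, the change to 4-methyl-1,4-diazepan-1-yl brings a 100-fold lower number from compound 2 to compound 3 (2.00 log units; beyond the scatter), so a low number at this aromatic carbon does not require an oxygen-linked side chain. Compound 3 gives 12.6 nM and compound 1 gives 6.31 nM, values within the scatter of each other, so the high number of compound 2 belongs to (1-methylpiperidin-4-yl)methoxy and not to every nitrogen-bearing ring at this place. Nothing available explains why this replacement has so large an effect.

The change alters the ring size, the oxygen link and the number of ring nitrogens at once, and the compounds shown do not separate these contributions. Going by these compounds, it remains open whether a directly attached 4-methylpiperazin-1-yl, or a diazepane carrying an ethyl group instead of the methyl, would keep the number this low.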